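A few compounds are considered here, and "the series" means these few. Any claim that something is new, unique, unknown or untested is made for them only; others in the source may bear on it.

Of the compounds shown here, three that share one core have been tested in an ADME assay on U-937 cells (Homo sapiens) for inhibition, read by CellTiter-Glo, with a stated time of 72 h; a higher number here means a weaker inhibitor of growth, a lower number a stronger inhibitor of growth. Compound 1 `Cc1ccc(Nc2ncc3c(n2)N(C)C(=O)N(c2cc(NC(=O)c4ccc(-n5cccc5)c(C(F)(F)F)c4)ccc2C)C3)cn1` gives > 25000 nM, which is a limit of the assay and not a number. Compound 3 `Cc1ccc(NC(=O)c2cccc(C(F)(F)F)c2)cc1N1Cc2cnc(Nc3cnn(C)c3)nc2N(C)C1=O` gives 1130 nM. Compound 2 `CCN1CCN(C(=O)c2ccc(Nc3ncc4c(n3)N(C)C(=O)N(c3cc(NC(=O)c5cccc(C(F)(F)F)c5)ccc3C)C4)cn2)CC1` gives 6480 nM, the higher of the two actual numbers, and this gap lies beyond the scatter. Compound 4 `CCN1CCN(c2ccc(Nc3ncc4c(n3)N(C)C(=O)N(c3cc(NC(=O)c5cccc(C(F)(F)F)c5)ccc3C)C4)cn2)CC1` differs from compound 2 in one place: 4-ethylpiperazin-1-yl in place of (4-ethylpiperazin-1-yl)carbonyl on an aromatic carbon. In words, 4-ethylpiperazin-1-yl stands in place of (4-ethylpiperazin-1-yl)carbonyl on an aromatic carbon. Among the measured compounds shown here, no measured pair shows this change, so the forecast is uncertain. A modest move toward a lower number is expected, with the estimated step of a 2.3-fold lower number from compound 2 to compound 4 (0.36 log units; beyond the scatter). For compound 4 the estimated value is 2800 nM, with an expected range from 700 nM to 11000 nM.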

Compound 4, concentration for 50% growth inhibition: 1410 nM
Beside the measured number, compound 4's estimate is 2.0-fold (0.30 log units) above it; the range from low to high includes it.
By their numbers in this assay, from the lowest: compounds 3 and 4 (each within the scatter of the next); then compound 2. At a limit, above all of these: compound 1.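

In this assay, replacing (4-ethylpiperazin-1-yl)carbonyl with 4-ethylpiperazin-1-yl gives a 4.6-fold lower number from compound 2 to compound 4 (0.66 log units; beyond the scatter) and is the only single-place comparison shown. It shows that growth inhibition responds to a change at this place on the six-membered aromatic ring with 1 nitrogen, with the carbonyl absent in the compound giving the lower number. Nothing measured here explains this step. Still open, as far as these compounds go, is whether the ethyl group matters, and how a morpholine ring or a dimethylamino group would read at this place.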